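Cyclohexylmethyl in place of phenyl on the imidazole carbon

The source may hold more compounds than are shown below. What is called first, only, known or untested is meant among the compounds shown, and "the series" means these compounds.

The series shares the core of compound 1 `O=C(O)c1ccccc1-c1ccc(CCc2ncc(Cc3cccc(Cl)c3)[nH]2)cc1` and varies the group on the five-membered ring. In an in vitro functional assay on cells for agonist activity at Bombesin receptor subtype-3 (Mus musculus), read by luminescence and calcium flux (on this read-out lower numbers stand for an effect already at smaller amounts and higher numbers for an effect only at larger amounts of compound), compound 1 gives 31 nM. Within the data shown here, compound 2 `O=C(O)c1ccccc1-c1ccc(CCc2ncc(-c3ccccc3)[nH]2)cc1` gives 872 nM in this assay, the highest of the two numbers measured so far; the only nearest point is compound 1, and the step of a 28-fold higher number from compound 1 to compound 2 (1.45 log units; beyond the scatter) is the single measured step that bears here. Compound 3 `O=C(O)c1ccccc1-c1ccc(CCc2ncc(CC3CCCCC3)[nH]2)cc1` differs from compound 2 by cyclohexylmethyl in place of phenyl on an aromatic carbon. Cyclohexylmethyl resembles 3-chlorobenzyl in its attachment more than phenyl does, so the expectation is a partial reversal of the step seen from compound 1 to compound 2, that is a lower number in this assay for compound 3, estimated as a 5.8-fold lower number from compound 2 to compound 3 (0.76 log units; beyond the scatter). Compound 3 is expected to give about 150 nM in this assay, with a range from 40 nM to 600 nM.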

Compound 3, half-maximal effective concentration: 7.3 nM
Beside the measured number, compound 3's estimate is 21-fold (1.31 log units) above it; the measured number lies below the stated range.
By their numbers in this assay, from the lowest: compound 3; then compound 1; then compound 2.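

Working from the phenyl of compound 2, cyclohexylmethyl at this carbon of the five-membered aromatic ring gives a 120-fold lower number from compound 2 to compound 3 (2.08 log units; beyond the scatter) in this assay and so recovers more than the loss seen with phenyl. An aromatic ring on the saturated chain carbon is not required for a low number here, as cyclohexyl in place of 3-chlorophenyl gives a 4.2-fold lower number from compound 1 to compound 3 (0.63 log units; beyond the scatter) and compound 3 has the lowest number of the three. No supporting data offer an explanation for either step.

The change from compound 2 to compound 3 alters both the ring and the chain carbon, so the contribution of each stays unseparated; unsubstituted benzyl or cyclohexyl on the aromatic carbon would divide them. Also open, from the compounds shown here alone, is how a longer chain such as cyclohexylethyl, or an amine on the cyclohexyl ring, would read.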